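Cytotoxicity Across Three Measured Compounds and One Expected

The source may hold more compounds than are shown below. What is called first, only, known or untested is meant among the compounds shown, and "the series" means these compounds.

Compound 1 `CC(C)N(Cc1cccc(OCCCCCC(=O)O)c1)C(=O)c1ccc(-c2cccc(OCc3ccccc3)c2)cc1`: in an ADME assay on HEK293 cells (Homo sapiens) for cytotoxicity, read by CellTiter-Glo and resazurin assay, with a stated time of 72 h (on this read-out higher numbers stand for an effect only at larger amounts of compound and lower numbers for an effect already at smaller amounts), compound 1 gives > 26000 nM, which is a limit of the assay and not a number.
Compound 2 `Cc1nnc(-c2cccc(-c3ccc(C(=O)N(Cc4cccc(OCCCCCC(=O)O)c4)C(C)C)cc3)c2)o1`: in this assay compound 2 gives > 26000 nM, likewise a limit.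
Compound 3 `CCOC(=O)CCCCCOc1cccc(CN(C(=O)c2ccc(-c3cccc(OCc4ccccc4)c3)cc2)C(C)C)c1`: in this assay compound 3 gives > 26000 nM, again a limit.

Compound 2 differs from compound 1 by 5-methyl-1,3,4-oxadiazol-2-yl in place of benzyloxy on an aromatic carbon. The resulting step is a step that the two limits leave unreadable from compound 1 to compound 2. Compound 3 differs from compound 1 by ethyl in place of hydrogen on an oxygen next to a carbonyl group, and that step is a step that the two limits leave unreadable from compound 1 to compound 3. Neither step can be sized because of the limit of > 26000 nM in this assay, at which 3 of the 3 values shown sit.

Compound 4 `CCOC(=O)CCCCCOc1cccc(CN(C(=O)c2ccc(-c3cccc(-c4nnc(C)o4)c3)cc2)C(C)C)c1` has not yet been measured. It differs from compound 3 by 5-methyl-1,3,4-oxadiazol-2-yl in place of benzyloxy on an aromatic carbon. The place is described in the same words as for the change from compound 1 to compound 2, so this is the same change, seen here for the second time.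

In this assay compound 4 is expected to show 40000 nM, with a range from 20000 nM to 120000 nM. This amounts to an expected step that the limit leaves unreadable from compound 3 to compound 4. The expectation rests on the step that the two limits leave unreadable from compound 1 to compound 2, which the same change produced where both of its ends sit at the limit named in the limit of > 26000 nM in this assay, at which 3 of the 3 values shown sit, and on compound 3 itself sitting at that limit.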

Compound 4, half-maximal effective concentration: > 26000 nM
Compound 4 was reported as a limit; the forecaster's own chance of this, stated with the estimate: 85%; the middle value does not contradict the limit.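

In this assay compound 4 gives > 26000 nM, a limit of the assay and not a number. Neither the step from compound 3 to compound 4 nor the step from compound 2 to compound 4 can be read, because both ends of each sit at the same limit: the limit of > 26000 nM in this assay, at which 4 of the 4 values shown sit.

The compounds shown leave open at what concentration any of the four has an effect on these cells, and so whether either change shifts that concentration at all.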